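A But-2-yn-1-yl Group in Place of Cyclopropyl

The compounds below may be only part of what the source reports. "The series", "measured", "known", "first", "only" and "open" are said of these compounds alone.

Of the compounds shown here, three sharing one core have been measured in an ADME assay on microsomes from liver (Homo sapiens) for metabolic stability, with a stated time of 30 min; on this read-out higher numbers stand for a more stable compound and lower numbers for a less stable compound. Compound 1 `CCCCOC(=O)Cc1c(C(C)C)nc(CCCC)n(Cc2ccc(-c3ccccc3-c3noc(=O)[nH]3)cc2)c1=O` gives 7.1%. Compound 2 `CCCCc1nc(C(C)C)c(CC(=O)OCC(C)C)c(=O)n1Cc1ccc(-c2ccccc2-c2noc(=O)[nH]2)cc1` gives 8.8%, and compound 3 `CCCCc1nc(C(C)C)c(CC(=O)OC2CC2)c(=O)n1Cc1ccc(-c2ccccc2-c2noc(=O)[nH]2)cc1` gives 10.3%. Compound 3 holds the highest of the three numbers, yet its distance to compound 2 and to compound 1 lies within the scatter, so no order among the three can be drawn from these figures. Within the data shown here, every measured step so far alters only the group on an oxygen next to a carbonyl group: a number 1.7 percentage points higher from compound 1 to compound 2 (within the scatter), a number 3.2 percentage points higher from compound 1 to compound 3 (within the scatter) and a number 1.5 percentage points higher from compound 2 to compound 3 (within the scatter), each of them within the scatter.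

Compound 4 `CC#CCOC(=O)Cc1c(C(C)C)nc(CCCC)n(Cc2ccc(-c3ccccc3-c3noc(=O)[nH]3)cc2)c1=O` has not yet been measured in this assay. It differs from compound 3 by but-2-yn-1-yl in place of cyclopropyl on an oxygen next to a carbonyl group. This change sits at the same place as the three measured steps, and none of those steps moved the read-out beyond the scatter, so a step of comparable size, and none beyond the scatter, is expected here: the estimated step is a number 0.3 percentage points lower from compound 3 to compound 4 (within the scatter). Compound 4 is therefore expected to give 10%, with a range from 3% to 20%.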

Compound 4, percent of the compound remaining: 13.7%
The estimate for compound 4 lay 3.7 percentage points below the measured number, and the stated range covers the measured number.
By their numbers in this assay, from the lowest: compounds 1, 2, 3 and 4 (each within the scatter of the next).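

Among these compounds, with a triple bond outside aromatic rings now on an oxygen next to a carbonyl group, where the earlier compounds carried only butyl, isobutyl or cyclopropyl, the result in this assay remains inside the usual spread of repeated measurements, at a number 3.4 percentage points higher from compound 3 to compound 4 (within the scatter), a number 4.9 percentage points higher from compound 2 to compound 4 (within the scatter) and a number 6.6 percentage points higher from compound 1 to compound 4 (within the scatter). Among the compounds shown here, this widens the range of groups tried at this position to an open chain with a triple bond, and even the largest of these steps, the one from the butyl compound, gives no readable difference, so the four compounds still cannot be placed in a firm order. Nothing available bears on this result, and the numbers alone offer no explanation for it.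

As far as these compounds go, it remains open whether any group on this oxygen can shift the read-out beyond the scatter, for example a chain ending in an amine or a benzyl group, or whether replacing the whole group to give the free carboxylic acid would do so. Also open, from the compounds shown here alone, is how far changes elsewhere on the shared core, such as a shorter chain in place of the butyl group on the ring, would move these numbers.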